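Compound 4: swapping pyridin-4-yl for phenyl

The source may hold more compounds than are shown below. What is called first, only, known or untested is meant among the compounds shown, and "the series" means these compounds.

Measured so far in a functional assay on SK-OV-3 cells (Homo sapiens) for inhibition, read by CCK-8 assay, with a stated time of 70 h (a higher number here means a weaker inhibitor, a lower number a stronger inhibitor), as follows.
- Compound 1 `c1ccc(COc2ccc(OCCOCCOC3CCCC3)cc2)cc1` gives > 100000 nM as a limit
- Compound 2 `O=C(O)c1cccc(COc2ccc(OCCOCCNC3CCCC3)cc2)c1` gives > 100000 nM as a limit
- Compound 3 `c1ccc(COc2ccc(OCCOCCNc3ccncc3)cc2)cc1` gives 20600 nM as a number

Among the measured compounds shown here, compound 3 holds the only true number here. The other two results are limits (the limit of > 100000 nM in this assay, at which 2 of the 3 values shown sit).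

Compound 4 `c1ccc(COc2ccc(OCCOCCNc3ccccc3)cc2)cc1` carries phenyl in place of pyridin-4-yl on an amine nitrogen as its change, phenyl in place of pyridin-4-yl on an amine nitrogen. For the measured compounds named here, the only measured step touching this place is an at least 4.8-fold lower number from compound 1 to compound 3 (0.68 log units; beyond the scatter) and it replaced cyclopentyloxy, so it bears only loosely on this swap. Going by the values given here, compound 3, which carries pyridin-4-yl, is the one compound with a number, so a modest move toward a higher number in this assay is expected. The estimated step is a 1.5-fold higher number from compound 3 to compound 4 (0.16 log units; within the scatter) and it may not clear the scatter. Compound 4 is estimated at 30000 nM with an expected range of 10000 nM to 90000 nM in this series.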

Compound 4, half-maximal inhibitory concentration: > 100000 nM
Compound 4: only a limit was reported; the forecaster's own chance of this, stated with the estimate: 25%; middle value at least 3.3-fold (0.52 log units) away from the limit.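

In this assay, phenyl in place of pyridin-4-yl on an amine nitrogen gives an at least 4.8-fold higher number from compound 3 to compound 4 (0.68 log units; beyond the scatter), so an aromatic ring at this place is not enough on its own, and the change of a single ring atom separates a measurable value from none. The step from compound 1 to compound 4 cannot be read, as both values are limits. Compound 3 remains the only compound clear of the limit: the limit of > 100000 nM in this assay, at which 3 of the 4 values shown sit.

Still open, from the compounds shown here alone, is whether the ring nitrogen must sit as in pyridin-4-yl, or whether pyridin-3-yl or pyrimidinyl on the same amine nitrogen would also hold a measurable value.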